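Swapping the Benzyl Group for 4-Phenylphenyl

The source may hold more compounds than are shown below. What is called first, only, known or untested is meant among the compounds shown, and "the series" means these compounds.

Compound 1 `Cc1ccc(CN2CCc3ncn(COCc4ccccc4)c3/C(=C/c3ccccc3)C2=O)cc1`: 11400 nM
Compound 2 `Cc1cc(C)cc(CN2CCc3ncn(COCc4ccccc4)c3/C(=C/c3ccccc3)C2=O)c1`: 22500 nM

In a functional assay on A549 cells (Homo sapiens) for inhibition, read by MTT assay, with a stated time of 72 h (a higher number here means a weaker inhibitor, a lower number a stronger inhibitor), compound 2 stands at 22500 nM, and compound 1 gives 11400 nM, so the two cannot be ranked. Among the measured compounds shown here, the only measured step, a 2.0-fold higher number from compound 1 to compound 2 (0.30 log units; within the scatter), changes the group at the same place that now changes again. Compound 3 `O=C1/C(=C\c2ccccc2)c2c(ncn2COCc2ccccc2)CCN1Cc1ccc(-c2ccccc2)cc1` is not yet measured. It carries 4-phenylphenyl in place of 3,5-dimethylphenyl on a saturated chain carbon bound to an amide-type nitrogen in a ring. That single step stays within the scatter, and neither measured compound holds 4-phenylphenyl, so the guidance is thin and the range is kept wide. No step beyond the scatter is expected, and the estimated change is a 1.3-fold lower number from compound 2 to compound 3 (0.10 log units; within the scatter). Compound 3 is estimated at 18000 nM, with an expected range of 7000 nM to 45000 nM.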

Compound 3, half-maximal inhibitory concentration: 18300 nM
Beside the measured number, compound 3's estimate is 1.0-fold (0.01 log units) below it; low and high end bracket the measured number.
By their numbers in this assay, from the lowest: compounds 1, 3 and 2 (each within the scatter of the next).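

In this assay, 4-phenylphenyl brings a second six-membered aromatic ring of carbon only to the saturated chain carbon bound to an amide-type nitrogen in a ring, in place of 3,5-dimethylphenyl, and this gives a 1.2-fold lower number from compound 2 to compound 3 (0.09 log units; within the scatter) while phenyl in place of methyl on an aromatic carbon gives a 1.6-fold higher number from compound 1 to compound 3 (0.21 log units; within the scatter) as the reading against the 4-methylphenyl of compound 1. The earlier pair showed only methyl-bearing single rings at this place, whereas compound 3 shows that a group of two rings also stays within the scatter of both. No measurement here offers a reason for this.

From the compounds shown here alone, all three groups at this place are built of carbon only, so it remains open whether an amine or a carboxylic acid on the ring would give a different number. Going by these compounds, a longer chain between the ring and the amide-type nitrogen is equally open.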